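Acylating the Ring Nitrogen of a Weak Cytotoxic Amide

The compounds below may be only part of what the source reports. "The series", "measured", "known", "first", "only" and "open" are said of these compounds alone.

Measured compounds:
Compound 1, `O=C(Nc1ccccc1O)C1CCc2ccccc2N1`: 2680 nM
Compound 2, `O=C(Nc1ccccc1C(F)(F)F)C1CCc2ccccc2N1`: 39300 nM

Both were tested in a functional assay on NUGC-3 cells (Homo sapiens) for cytotoxicity, read by sulforhodamine B assay, with a stated time of 72 h; a higher number here means a weaker inhibitor of growth, a lower number a stronger inhibitor of growth. Within the data shown here, compound 2 stands at the highest of the two numbers; its only neighbour is compound 1, separated by the step of a 15-fold higher number from compound 1 to compound 2 (1.17 log units; beyond the scatter), which came with trifluoromethyl in place of hydroxy on an aromatic carbon.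

Compound 3, `CCC(=O)N1c2ccccc2CCC1C(=O)Nc1ccccc1C(F)(F)F`, has not yet been measured. It differs from compound 2 as follows: propanoyl in place of hydrogen on a nitrogen on an aromatic ring in a ring. Among the measured compounds shown here, no measured step bears on this kind of change: the single step available, a 15-fold higher number from compound 1 to compound 2 (1.17 log units; beyond the scatter), concerns a different group, and the data hold no example of a propanoyl entering at a nitrogen. There is thus no measured guide for direction or size, and the expectation can only start from the number for compound 2. The expected step in this assay is therefore none beyond the scatter, with wide uncertainty in both directions. Compound 3 is estimated at 50000 nM, with a range from 15000 nM to 160000 nM. This estimate for compound 3 means an expected step of a 1.3-fold higher number from compound 2 to compound 3 (0.10 log units; within the scatter).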

Compound 3, concentration for 50% growth inhibition: > 80000 nM
Compound 3 ended at the assay's limit; the forecaster's own chance of this, stated with the estimate: 25%; at least 1.6-fold (0.20 log units) between middle value and limit.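

Compound 1 and compound 2 differ only in hydroxy against trifluoromethyl, so they said nothing about the nitrogen on an aromatic ring in a ring; at this position, propanoyl in place of hydrogen gives an at least 2.0-fold higher number from compound 2 to compound 3 (0.30 log units; that floor lies within the scatter) in this assay. Among these compounds, compound 3 stands at a limit of the assay rather than at a number: the limit of > 80000 nM in this assay, at which 1 of the 3 values shown sits. This shows for the first time that, on compound 2, putting propanoyl on this nitrogen does not bring the number down, but the true size of the step cannot be read, and its floor alone does not separate the two compounds beyond the scatter.

What the compounds shown leave open is whether this result belongs to propanoyl in particular or to any group at this nitrogen, since an acetyl or a longer chain ending in an amine could give a different number. From the compounds shown here alone, it is also open whether propanoyl would act in the same way on compound 1, which carries hydroxy in place of trifluoromethyl and has the lower number of that pair.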